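The source may report more compounds than this note shows. Statements on the series, on what has been measured and on what is new or still open speak of the compounds shown alone.

Working notes on the caffeoyl amino ester series in a functional assay, read by spectrophotometry, with a stated time of 30 min; on this read-out higher numbers stand for weaker inhibition and lower numbers for stronger inhibition.

Compound 1 `CCOC(=O)[C@H](C)NC(=O)/C=C/c1ccc(O)c(O)c1` gives 29700 nM in compound 1's measurement in this assay. Compound 2 `CCOC(=O)[C@@H](NC(=O)/C=C/c1ccc(O)c(O)c1)[C@@H](C)CC` gives 43500 nM in this assay, the higher of the two numbers in hand, though the step of a 1.5-fold higher number from compound 1 to compound 2 (0.17 log units; within the scatter) lies within the scatter, so the two values show no difference that can be read as order.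

Compound 3 `CCOC(=O)CNC(=O)/C=C/c1ccc(O)c(O)c1` is not yet measured in this assay. It differs from compound 2 in one place: hydrogen in place of sec-butyl on a saturated chain carbon bound to an amide-type nitrogen and a carbonyl carbon. Among the compounds with values here, the only measured step that bears on this place is a 1.5-fold higher number from compound 1 to compound 2 (0.17 log units; within the scatter), where the change from methyl to sec-butyl at the same carbon stayed within the scatter. On that basis the further shortening to hydrogen is expected to give no step beyond the scatter; the expected step is a 1.4-fold lower number from compound 2 to compound 3 (0.13 log units; within the scatter).

Compound 3 is therefore estimated at 32000 nM, with a range from 13000 nM to 80000 nM.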

Compound 3, half-maximal inhibitory concentration: 18600 nM
Beside the measured number, compound 3's estimate is 1.7-fold (0.24 log units) above it, within the range that was stated.
By their numbers in this assay, from the lowest: compounds 3, 1 and 2 (each within the scatter of the next, the first and the last beyond it).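

Hydrogen in place of sec-butyl gives the only step at this carbon that lies beyond the scatter, a 2.3-fold lower number from compound 2 to compound 3 (0.37 log units; beyond the scatter), a modest separation that the comparison of methyl with sec-butyl did not show. Hydrogen in place of methyl, a 1.6-fold lower number from compound 1 to compound 3 (0.20 log units; within the scatter), stays within the scatter, so among these three groups only hydrogen and sec-butyl can be told apart, and methyl cannot be separated from either. No evidence is available that accounts for this step.

The compounds shown leave open how a longer straight chain, a benzyl group or a chain bearing an amine at this same carbon would read in this assay. They also leave open whether the separation between hydrogen and sec-butyl would hold with a carboxylic acid in place of the ethyl ester.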